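From Bromo to Cyano on the Phenyl Ring

This account rests on a few compounds, and the source may have more. Where it says the series, first, only, none or still open, it means among the compounds named here.

Of the compounds shown here, two on one shared core have numbers so far in a functional assay on MDA-MB-231 cells (Homo sapiens) for inhibition, read by MTT assay, with a stated time of 5 days (on this read-out lower numbers stand for stronger inhibition and higher numbers for weaker inhibition), and both carry a substituted phenyl ring. Compound 1 (`Cc1cc(Nc2nc(NCc3cccc(Cl)c3)nc3[nH]ncc23)n[nH]1`) gives 6860 nM as its result. Compound 2 (`Cc1cc(Nc2nc(NCc3ccc(Br)cc3)nc3[nH]ncc23)n[nH]1`) gives 1860 nM as the lower of the two numbers and stands as the better inhibitor of this pair. Compound 3 (`Cc1cc(Nc2nc(NCc3ccc(C#N)cc3)nc3[nH]ncc23)n[nH]1`) differs from compound 2 in one place, with cyano in place of bromo on an aromatic carbon. The new group sits para to a large group. For the measured compounds named here, only one measured step bears on this: 4-bromophenyl in place of 3-chlorophenyl gave a 3.7-fold lower number from compound 1 to compound 2 (0.57 log units; beyond the scatter) and that was modest. It involved other groups. It shows how far a change on this ring has moved the number, but not which way cyano will push it. A step of about that size or smaller is expected. Going by the values given here, the lean is towards a higher number because compound 2 at 1860 nM is the lowest value so far. The expected move in this assay is a 1.5-fold higher number from compound 2 to compound 3 (0.18 log units; within the scatter) as an estimate. Compound 3 is estimated at 2800 nM with an expected range from 900 nM to 8000 nM for the coming measurement.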

Compound 3, half-maximal inhibitory concentration: 1360 nM
Compound 3: middle estimate off by 2.1-fold (0.31 log units), on the high side; the measured number falls inside the stated range.
By their numbers in this assay, from the lowest: compounds 3 and 2 (each within the scatter of the next); then compound 1.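

On the 4-position of this phenyl ring, cyano and bromo cannot be told apart in this assay: the exchange gives a 1.4-fold lower number from compound 2 to compound 3 (0.14 log units; within the scatter). This holds even though the exchange replaces a single bromine atom with the two heavy atoms of cyano and adds one hydrogen-bond acceptor, so the position accepts two quite different groups with no change beyond the scatter. The gap to the 3-chlorophenyl compound is now seen with a second group as well, at a 5.0-fold lower number from compound 1 to compound 3 (0.70 log units; beyond the scatter), and none of the data shown offer an explanation for either step.

Compound 1 differs from compound 2 and compound 3 in both the identity and the place of its ring substituent, so these compounds cannot show which of the two matters; a 4-chlorophenyl ring would separate them. On these data alone, it also remains open how this position responds to groups of other kinds, such as an amine, a carboxylic acid or a longer chain.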